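The source may report more compounds than this note shows. Statements on the series, on what has been measured and on what is new or still open speak of the compounds shown alone.

Compound 1 `N=S1(=O)CC(Nc2nonc2/C(=N/O)Nc2ccc(F)c(Br)c2)C1` gives 208 nM in an assay on isolated protein for inhibition of Indoleamine 2,3-dioxygenase 1 (Homo sapiens), read by fluorescence, with a stated time of 60 min; on this read-out lower numbers stand for stronger inhibition and higher numbers for weaker inhibition. Compound 2 `CN(C)S(=O)(=O)CCNc1nonc1/C(=N/O)Nc1ccc(F)c(Br)c1` gives 105 nM in this assay.

Among the compounds with values here, of the two numbers, compound 2 holds the one reached by the step of a 2.0-fold lower number from compound 1 to compound 2 (0.30 log units; within the scatter), and that step lies within the usual scatter, so the two compounds cannot be told apart on these data. Compound 3 `O=S(=O)(CCNc1nonc1/C(=N/O)Nc1ccc(F)c(Br)c1)NCC1CC1` differs from compound 2 by (cyclopropylmethyl)amino in place of dimethylamino on a sulfonyl sulfur, a change of the amine attached to the sulfonyl group. Within the data shown here, the only measured step, a 2.0-fold lower number from compound 1 to compound 2 (0.30 log units; within the scatter), swapped the whole group on the aromatic-ring nitrogen, not just the amine on sulfur, and it stayed within the scatter; no step touches the present change directly. With nothing pointing either way, the expected step of a 1.0-fold higher number from compound 2 to compound 3 (0.02 log units; within the scatter) in this assay is none beyond the scatter. Compound 3 is therefore estimated at 110 nM in this assay, with a range from 40 nM to 300 nM.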

Compound 3, half-maximal inhibitory concentration: 312 nM
Compound 3: middle estimate off by 2.8-fold (0.45 log units), on the low side, outside the stated range (above it).
By their numbers in this assay, from the lowest: compounds 2, 1 and 3 (each within the scatter of the next, the first and the last beyond it).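

Swapping dimethylamino for (cyclopropylmethyl)amino on the sulfonyl sulfur gives a 3.0-fold higher number from compound 2 to compound 3 (0.47 log units; beyond the scatter) in this assay, so the amine on this sulfur is not a silent position: the change weakens inhibition modestly, and it is the first single change here to clear the scatter. The entering group differs from the leaving one in several ways at once, with more heavy atoms, a three-membered ring and a hydrogen-bond donor, and this one step cannot separate them. Nothing measured here bears on why the number rises.

As far as these compounds go, it remains open whether a smaller group on this sulfur, such as methylamino, would read closer to compound 2 or to compound 3. Also open, from the compounds shown here alone, is how (cyclopropylmethyl)methylamino, which keeps the ring but carries no hydrogen on its nitrogen, would compare.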